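Stereochemical definition in the aldehyde series: compound 3 to compound 4

A few compounds are considered here, and "the series" means these few. Any claim that something is new, unique, unknown or untested is made for them only; others in the source may bear on it.

Three compounds sharing one core have been run in a functional assay on Hep 3B2 cells (Homo sapiens) for cytotoxicity, read by MTT assay, with a stated time of 48 h; a higher number here means a weaker inhibitor, a lower number a stronger inhibitor. Compound 1 `COc1cc([C@@H]2Oc3c(OC)cc(/C=C/C=O)cc3[C@H]2CO)cc(OC)c1O`, drawn with both ring stereocentres defined, gives 60700 nM. Among the compounds with values here, compound 2 `COc1cc(C2Oc3c(OC)cc(/C=C/C=O)cc3C2CO)cc(OC)c1O`, the same atoms and bonds with the two ring stereocentres left undefined, gives 76800 nM; the step of a 1.3-fold higher number from compound 1 to compound 2 (0.10 log units; within the scatter), and the only difference between the pair is the fact that one of compounds 1 and 2 is drawn with a defined configuration and the other without, at the place where they differ. Compound 3 `COc1cc(C2Oc3c(OC)cc(/C=C/C=O)cc3C2CO)ccc1O`, with hydrogen in place of methoxy on an aromatic carbon, gives 29300 nM; the step of a 2.6-fold lower number from compound 2 to compound 3 (0.42 log units; beyond the scatter). Compound 3 thus stands lowest of the three numbers, beyond the scatter from both compound 1 and compound 2.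

Compound 4 `COc1cc([C@H]2Oc3c(OC)cc(/C=C/C=O)cc3[C@@H]2CO)ccc1O` is not yet measured. Its difference from compound 3 is the two compounds have the same atoms and bonds; at least one stereo element is drawn with a configuration in one of them and without one in the other: 2 of 3 stereo elements differ; a stereocentre at a saturated ring carbon is drawn without a configuration in compound 3 and S in compound 4; a stereocentre at a saturated ring carbon is drawn without a configuration in compound 3 and R in compound 4. Within the data shown here, the one measured step that bears on this kind of change is the step from compound 1 to compound 2, where adding or removing drawn configuration at the same two ring carbons moved the number within the scatter. On that basis no step beyond the scatter is expected here, and the estimated step is a 1.1-fold lower number from compound 3 to compound 4 (0.05 log units; within the scatter). Compound 4 is therefore estimated at 26000 nM in this assay, with a range from 12000 nM to 58000 nM.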

Compound 4, half-maximal inhibitory concentration: 22400 nM
The estimate for compound 4 lay 1.2-fold (0.06 log units) above the measured number; measured number inside the range.
By their numbers in this assay, from the lowest: compounds 4 and 3 (each within the scatter of the next); then compounds 1 and 2 (each within the scatter of the next).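

In this assay the step with hydrogen in place of methoxy on an aromatic carbon is within the scatter (a 1.3-fold lower number from compound 3 to compound 4 (0.12 log units; within the scatter)), so drawing the two ring stereocentres with a defined configuration changes no reading on this substitution. The earlier pair showed this only with the methoxy present (a 1.3-fold higher number from compound 1 to compound 2 (0.10 log units; within the scatter)), and the two steps together now cover both substitutions at that aromatic carbon, each staying within the scatter. The reading of the new step rests on one difference alone: the fact that one of compounds 3 and 4 is drawn with a defined configuration and the other without, at the place where they differ.

The compounds shown hold no pair with the same substitution and the two ring stereocentres drawn in opposite configurations, and what the undefined drawings of compound 2 and compound 3 contain is not stated, so whether configuration at these carbons matters at all in this assay remains open. Also open, as far as these compounds go, is how the number responds to a change away from the stereocentres, such as a carboxylic acid or an amine in place of the aldehyde on the shared core.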